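Swapping Trifluoromethyl for Trifluoromethoxy on the Sulfonyl Ring

This account rests on a few compounds, and the source may have more. Where it says the series, first, only, none or still open, it means among the compounds named here.

Measured so far:
compound 1 `CN1CCN(c2ccc(C3=NN(S(=O)(=O)c4ccc(OC(F)(F)F)cc4)C(c4ccc(N(C)C)cc4)C3)cc2)CC1` gives 70.8%
compound 2 `CN(C)c1ccc(C2CC(c3ccc(-n4cncn4)cc3)=NN2S(=O)(=O)c2ccc(C(F)(F)F)cc2)cc1` gives 37%

In a functional assay on HCC1806 cells (Homo sapiens) for inhibition, read by sulforhodamine B assay, tested at 10 uM (a lower number here means less inhibition, a higher number more inhibition at the concentration tested (going by the name of the read-out)), compound 1 gives 70.8% and compound 2 gives 37%, the lower of the two numbers and beyond the scatter below compound 1. These two structures differ in more than one place, so no single step can be read from them. Compound 3 `CN(C)c1ccc(C2CC(c3ccc(-n4cncn4)cc3)=NN2S(=O)(=O)c2ccc(OC(F)(F)F)cc2)cc1` differs from compound 2 in one place only: trifluoromethoxy in place of trifluoromethyl on an aromatic carbon. A small step is expected, a number 8 percentage points higher from compound 2 to compound 3 (within the scatter), with no firm direction and possibly none beyond the scatter. Compound 3 is estimated at 45%, between 20% and 70%.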

Compound 3, a percentage reported as inhibition, at one concentration (the size of the read-out at that concentration, not a potency): 25.2%
The estimate for compound 3 lay 19.8 percentage points above the measured number; low and high end bracket the measured number.
By their numbers in this assay, from the lowest: compound 3; then compound 2; then compound 1.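

In this assay, the change on this aromatic carbon has a measurable effect: trifluoromethoxy in place of trifluoromethyl gives a number 11.8 percentage points lower from compound 2 to compound 3 (beyond the scatter). Compound 3 also connects the two earlier structures, so the other end of the molecule can now be read: 1H-1,2,4-triazol-1-yl in place of 4-methylpiperazin-1-yl gives a number 45.6 percentage points lower from compound 1 to compound 3 (beyond the scatter), a much larger step. No available evidence explains either step.

The compounds shown leave open how a chlorine atom or a methoxy group would read on this aromatic carbon. They also leave open whether an open-chain amine in place of 4-methylpiperazin-1-yl would keep the higher number.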